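The compounds below may be only part of what the source reports. "The series", "measured", "known", "first", "only" and "open" are said of these compounds alone.

Measured so far:
compound 1, `N[C@H]1CC[C@H](N(C[C@H]2Cc3ccccc3CN2)[C@H]2CCCc3cccnc32)CC1`, 77% in an ADME assay on microsomes from liver (Mus musculus) for metabolic stability; a lower number here means that less of the compound is left, a higher number that more of the compound is left
compound 2, `C/C(=C/CN(C[C@H]1Cc2ccccc2CN1)[C@H]1CCCc2cccnc21)CN`, 2% in this assay

Compound 2 stands at the lowest of the two numbers in this assay. Its nearest neighbour is compound 1, and the step between them is a number 75 percentage points lower from compound 1 to compound 2 (beyond the scatter), a change on the amine nitrogen that replaces a ring-containing group with an open chain.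

Compound 3, `C/C(CN(C[C@H]1Cc2ccccc2CN1)[C@H]1CCCc2cccnc21)=C(/F)CN`, is not yet measured in this assay. It differs from compound 2 by a group of 6 heavy atoms (4 carbon, 1 nitrogen, 1 fluorine; no ring) in place of a group of 5 heavy atoms (4 carbon, 1 nitrogen; no ring), on a saturated chain carbon bound to an amine nitrogen.

Among the measured compounds shown here, no measured step touches this position or this kind of change; the single step known, from compound 1 to compound 2, concerns a different place and a different sort of group, so it gives no direct guidance for compound 3. What the numbers do show is that compound 2 in this assay leaves little room for a further fall. The expected step is therefore a number 6 percentage points higher from compound 2 to compound 3 (within the scatter), a small one. For compound 3 the estimated result in this assay is 8%, with a range from 1% to 30%.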

Compound 3, percent of the compound remaining: 15%
For compound 3 the middle estimate is 7 percentage points below the measured one; measured number inside the range.
By their numbers in this assay, from the lowest: compound 2; then compound 3; then compound 1.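

In this assay, the open chain proves sensitive to a small edit: the entry of 3-amino-2-fluoro-1-methylprop-1-en-1-yl, on a saturated chain carbon bound to an amine nitrogen, gives a number 13 percentage points higher from compound 2 to compound 3 (beyond the scatter) and so moves the number by more than the usual scatter, which the earlier pair could not show for this position. The gain remains limited, since the same compound still sits far from the ring-bearing compound, with a number 62 percentage points lower from compound 1 to compound 3 (beyond the scatter) on the amine nitrogen set against a number 75 percentage points lower from compound 1 to compound 2 (beyond the scatter) for the chain without fluorine, so the new chain recovers only a modest part of that fall. No measurement at hand bears on what lies behind this rise.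

The compounds shown leave open whether a chlorine atom or a methyl group in place of the fluorine would give a similar number, and whether a fully saturated chain would behave like these two unsaturated ones. They also leave open what a fluorine on the 4-aminocyclohexyl group would do to the high number of compound 1.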